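The source may report more compounds than this note shows. Statements on the series, on what has been measured and on what is new or still open speak of the compounds shown alone.

Working notes on the series. Compound 2 `CC(C)C[C@H](NC(=O)c1ccc(-c2ccccc2)cc1)C(=O)NC1(C#N)CC1` is the weaker of the two measured compounds in an assay on isolated protein for inhibition of cathepsin S (Homo sapiens); a lower number here means a stronger inhibitor, a higher number a weaker inhibitor: compound 2 gives 85 nM, while compound 1 `CC(C)C[C@H](NC(=O)c1ccc(-c2ccccc2)cc1)C(=O)NC1(C#N)CCS(=O)(=O)CC1` gives 1.1 nM. Among the compounds with values here, the only measured step, a 77-fold higher number from compound 1 to compound 2 (1.89 log units; beyond the scatter), concerns the 1-cyanocyclopropyl in place of 4-cyano-1,1-dioxothian-4-yl on an amide-type nitrogen and leaves the rest of the shared core untouched.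

Compound 3 `N#CC1(NC(=O)[C@H](CCCCN)NC(=O)c2ccc(-c3ccccc3)cc2)CC1` keeps the 1-cyanocyclopropyl of compound 2 and differs from it only at the saturated chain carbon: 3-aminopropyl in place of isopropyl on a saturated chain carbon, two bonds along the chain from an amide-type nitrogen and a carbonyl carbon. Within the data shown here, no measured pair touches that position, so the step from compound 1 to compound 2 does not bear on it, and nothing here tells how far a change at this carbon moves the number in this assay. Without a comparable step, the expectation for compound 3 can only be loose; a weakening relative to compound 2 is taken as somewhat more likely than a gain, with the estimated step of a 4.7-fold higher number from compound 2 to compound 3 (0.67 log units; beyond the scatter). Compound 3 is accordingly estimated at 400 nM in this assay, with a wide range from 60 nM to 3000 nM.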

Compound 3, half-maximal inhibitory concentration: > 5000 nM
Compound 3: only a limit was reported; the forecaster's own chance of this, stated with the estimate: 5%; middle value at least 12-fold (1.09 log units) from the limit.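

The saturated chain carbon, two bonds along the chain from an amide-type nitrogen and a carbonyl carbon, now has a measured step of its own in this assay, with an at least 58-fold higher number from compound 2 to compound 3 (1.76 log units; beyond the scatter), so the number responds strongly at this position as well as at the site changed between the earlier pair. Within the data shown here, the value of compound 3 is a limit of the assay and not a number, so the step gives only a lower bound on the size of the change: the limit of > 5000 nM in this assay, at which 1 of the 3 values shown sits. The finding rests on one exchange, isobutyl to 4-aminobutyl when cut one bond further out, made with the 1-cyanocyclopropyl kept in place, and it claims no pattern beyond that pair.

Still open, from the compounds shown here alone, is whether the step follows from the amine or from the length of the chain, a question that a plain butyl group or a carboxylic acid on the same chain would help to separate. Also open, going by these compounds, is whether the same exchange has a similar effect with 4-cyano-1,1-dioxothian-4-yl on the amide-type nitrogen, as in compound 1.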